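The source may report more compounds than this note shows. Statements on the series, on what has been measured and on what is new or still open speak of the compounds shown alone.

Measured compounds:
Compound 1, `C=CCc1cc(-c2cccc([N+](=O)[O-])c2)ccc1O`: in a functional assay on Lewis lung carcinoma cells (Mus musculus) for antiproliferative activity, read by MTT assay, with a stated time of 24 h (a lower number here means a stronger inhibitor, a higher number a weaker inhibitor), compound 1 gives > 100000 nM, which is a limit of the assay rather than a number.
Compound 2, `C=CCc1cc(-c2ccccc2)ccc1O`: in this assay compound 2 gives > 100000 nM, likewise a limit of the assay.

Compound 2 thus stands at the limit, with no numerical reading to place it against any neighbour. Going by the values given here, the one measured step, a step that the two limits leave unreadable from compound 1 to compound 2, cannot be read in size or direction, since both of its ends sit at the limit of > 100000 nM in this assay, at which 2 of the 2 values shown sit. Compound 3, `C=CCc1cc(-c2ccccc2C(F)(F)F)ccc1O`, differs from compound 2 by trifluoromethyl in place of hydrogen on an aromatic carbon. Among the compounds with values here, no measured step bears directly on this change, and the single step in the set is itself unreadable, so there is no quantitative guide to how large the step might be or which way it might go. With both measured compounds resting on the limit and nothing yet having moved a value off it, the expectation is that compound 3 also falls at or near the limit. The expected step is a step that the limit leaves unreadable from compound 2 to compound 3, meaning no change beyond the scatter. Compound 3 is therefore estimated at 150000 nM, within 40000 nM to 600000 nM.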

Compound 3, half-maximal inhibitory concentration: 60300 nM
Beside the measured number, compound 3's estimate is 2.5-fold (0.40 log units) above it, within the range that was stated.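

In this assay, going by these compounds alone, compound 3 gives 60300 nM, the first true number in the set. Trifluoromethyl in place of hydrogen, ortho to a large group, is thus the first change shown to bring a reading off the limit. The change reads as an at least 1.6-fold lower number from compound 2 to compound 3 (0.21 log units; that floor lies within the scatter), so this result alone does not establish a gain larger than the ordinary variation between repeated measurements, although the true step could be larger than this floor. Only a floor can be given, because compound 2 has a limit rather than a number at its end of the step, and the earlier step between the two limits still cannot be read: the limit of > 100000 nM in this assay, at which 2 of the 3 values shown sit.

The compounds shown leave open whether a smaller or different group at this same place, such as methyl, chlorine, methoxy, an amine or a carboxylic acid, would also give a number rather than a limit. They also leave open whether trifluoromethyl elsewhere on the same six-membered ring would give a similar reading, so nothing here yet shows how much this particular place matters.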